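Sulfonyl aryl swap and clearance in a quinoline series

A few compounds are considered here, and "the series" means these few. Any claim that something is new, unique, unknown or untested is made for them only; others in the source may bear on it.

Compound 1 `O=S(=O)(c1cc(F)cc(F)c1)c1cnc2cc(F)ccc2c1-c1cccc(F)c1` is measured in an ADME assay on microsomes from liver (Homo sapiens) for metabolic stability, tested at 2.5 uM; a higher number here means faster removal of the compound, a lower number slower removal; in this assay compound 1 gives 0.06 mL/min. Compound 2 `Cc1ccc(S(=O)(=O)c2cnc3cc(F)ccc3c2-c2cccc(F)c2)cc1F` differs from it by 3-fluoro-4-methylphenyl in place of 3,5-difluorophenyl on a sulfonyl sulfur, and in this assay compound 2 gives 0.41 mL/min, so that the change brought a 6.8-fold higher number from compound 1 to compound 2 (0.83 log units; beyond the scatter). Compound 3 `O=S(=O)(c1cc(F)cc(F)c1)c1cnc2c(F)cccc2c1-c1ccc(Cl)cc1` has a different core; how it differs from compound 1 is not broken down here. In this assay compound 3 gives 0.73 mL/min. Compound 4 `Cc1ccc(S(=O)(=O)c2cnc3c(F)cccc3c2-c2ccc(Cl)cc2)cc1F` is not yet measured; it differs from compound 3 by 3-fluoro-4-methylphenyl in place of 3,5-difluorophenyl on a sulfonyl sulfur, the same change as from compound 1 to compound 2. Because that earlier change gave a 6.8-fold higher number from compound 1 to compound 2 (0.83 log units; beyond the scatter), a step of similar size is expected here, namely a 5.5-fold higher number from compound 3 to compound 4 (0.74 log units; beyond the scatter). For compound 4 the estimated value in this assay is 4 mL/min, between 1.5 mL/min and 10 mL/min.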

Compound 4, intrinsic clearance in a liver preparation (reported as CLH), per the amount of preparation that the assay uses: 2.2 mL/min
The estimate for compound 4 lay 1.8-fold (0.26 log units) above the measured number; measured number inside the range.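

In this assay the change to 3-fluoro-4-methylphenyl in place of 3,5-difluorophenyl on the sulfonyl sulfur again raised the number, giving a 3.0-fold higher number from compound 3 to compound 4 (0.48 log units; beyond the scatter). Set beside the earlier step, the two run in the same direction and their sizes cannot be told apart: the same change on two cores in this assay, a 6.8-fold higher number (0.83 log units; beyond the scatter) from compound 1 to compound 2 and a 3.0-fold higher number (0.48 log units; beyond the scatter) from compound 3 to compound 4, 2.3-fold (0.36 log units) apart, within the scatter of two such steps This shows that the change carried over between these two cores in this assay, but it rests on a single pair of steps and does not show that the change would behave alike on any other core, nor why the number rises.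

The compounds shown leave open how an amine or a carboxylic acid on the sulfonyl aryl ring would fare in this assay. Also open, on these data alone, is what a plain alkyl chain in place of that ring would do.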